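The source may report more compounds than this note shows. Statements on the series, on what has been measured and on what is new or still open speak of the compounds shown alone.

- compound 1 `CN1CCN(C2CCN(c3nccc4[nH]c(-c5cc(F)cc(F)c5)nc34)CC2)CC1` gives 200000 nM
- compound 2 `CN1CCN(CC2CCN(c3nccc4[nH]c(-c5ccc(F)c(C(F)(F)F)c5)nc34)CC2)CC1` gives 165000 nM
- compound 3 `Fc1cc(F)cc(-c2nc3c(N4CCC(CN5CCNCC5)CC4)nccc3[nH]2)c1` gives 190000 nM

These three numbers come from a physicochemical assay for solubility, read by HPLC, using the shake flask method, in phosphate buffer, with a stated time of 20 h, at pH 6.5 (on this read-out lower numbers stand for lower solubility and higher numbers for higher solubility), and compound 3 stands level with the other two: its gaps to compound 1 and to compound 2 both lie within the usual scatter.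

The next structure is compound 4 `Fc1cc(F)cc(-c2nc3c(N4CCC(CN5CCC(F)(F)CC5)CC4)nccc3[nH]2)c1`, which has 4,4-difluoropiperidin-1-yl in place of piperazin-1-yl on a saturated chain carbon bound to a saturated ring carbon.

Going by the values given here, only one measured step bears on this change, and only loosely. Putting (piperazin-1-yl)methyl in place of 4-methylpiperazin-1-yl gave a 1.1-fold lower number from compound 1 to compound 3 (0.02 log units; within the scatter), so that swap left the number effectively unmoved. However, compound 1, compound 2 and compound 3 all carry a piperazin-1-yl or 4-methylpiperazin-1-yl group, so no measured compound shows what happens without one. Compound 2 differs from compound 3 in more than one place and offers no clean comparison.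

The small step therefore cannot simply be carried over, and the expectation here is a judgement with a wide range. The expected change is a 6.3-fold lower number from compound 3 to compound 4 (0.80 log units; beyond the scatter) in this assay, a move to a lower number beyond the scatter. For compound 4 the estimated value is 30000 nM, with 5000 nM to 120000 nM as the expected range.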

Compound 4, solubility: < 5000 nM
Compound 4: only a limit was reported; the forecaster's own chance of this, stated with the estimate: 5%; at least 6.0-fold (0.77 log units) between middle value and limit.
By their numbers in this assay, from the lowest: compounds 2, 3 and 1 (each within the scatter of the next). At a limit, below all of these: compound 4.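

In this assay, going by these compounds alone, moving from one piperazine-bearing group to another had told little, since neither compound left that family; this result is the first to show what happens when the piperazine itself goes. Placing 4,4-difluoropiperidin-1-yl in place of piperazin-1-yl on a saturated chain carbon bound to a saturated ring carbon gives an at least 38-fold lower number from compound 3 to compound 4 (1.57 log units; beyond the scatter), and the same comparison made from the methylated relative, (4,4-difluoropiperidin-1-yl)methyl in place of 4-methylpiperazin-1-yl on a saturated ring carbon, gives an at least 40-fold lower number from compound 1 to compound 4 (1.60 log units; beyond the scatter). Compound 4 sits at a limit and not at a number, so the full size of both steps stays unknown: the limit of < 5000 nM in this assay, at which 1 of the 4 values shown sits.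

The change alters the ring nitrogen, the hydrogen-bond donor and the fluorine atoms all at once, so a plain piperidin-1-yl or a morpholin-4-yl on the same chain carbon would be needed to tell which of these the drop follows. Going by these compounds, whether the same swap acts alike in the setting of compound 2 also stays open.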